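A few compounds are considered here, and "the series" means these few. Any claim that something is new, unique, unknown or untested is made for them only; others in the source may bear on it.

Compound 1 `O=C1NC(=S)/C(=C/c2cccc(Cl)c2)S1` — 18.8%
Compound 2 `O=C1NC(=S)/C(=C/c2ccccc2Cl)S1` — 21.2%

Both measured compounds share the same core and differ only in where a single chloro sits on the benzene ring. In a functional assay on HEp-2 cells (Homo sapiens) for cytotoxicity, read by MTT assay, with a stated time of 72 h, tested at 10 ug/mL (on this read-out higher numbers stand for more inhibition of growth at the one concentration tested and lower numbers for less inhibition of growth), compound 1 gives 18.8%, the lower of the two numbers. Compound 2 gives 21.2% in this assay, a number only slightly higher, a gap that falls within the scatter of this kind of measurement, so the two cannot be told apart.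

Compound 3 `O=C1NC(=S)/C(=C/c2cccc(F)c2)S1` is not yet measured. It differs from compound 1 by fluoro in place of chloro on an aromatic carbon. Among the measured compounds shown here, no measured pair in this set shows what such a swap of one halogen for another does, so nothing here tells whether a fluoro in that position raises or lowers growth inhibition. The two measured numbers sit close together and low, and there is no reason from this set to expect a change beyond the scatter.

The expected step of a number 0.8 percentage points lower from compound 1 to compound 3 (within the scatter) is therefore near zero, with a range wide enough to allow a modest shift either way. Compound 3 is estimated at 18%, between 6% and 32%.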

Compound 3, percent growth inhibition at one concentration: 20.9%
Beside the measured number, compound 3's estimate is 2.9 percentage points below it; the range from low to high includes it.
By their numbers in this assay, from the lowest: compounds 1, 3 and 2 (each within the scatter of the next).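

In this assay, among the compounds shown here, the first direct exchange of one halogen for another on this aromatic carbon gives a number 2.1 percentage points higher from compound 1 to compound 3 (within the scatter), so fluoro in place of chloro leaves the two compounds indistinguishable on this read-out. Compound 1 and compound 2 could not show this, as both carry the same halogen; this pair shows that, at this position, the choice between these two halogens makes no change that can be told from the usual scatter. No supporting measurement is available here to explain this result.

All three compounds carry a single halogen on the benzene ring, so the compounds shown leave open what a group of a different kind on this carbon, such as an amine, a carboxylic acid or a longer alkyl chain, would do to growth inhibition. They also leave open whether a larger halogen such as bromo would behave like chloro and fluoro here, and whether the same picture would hold at concentrations other than the single one tested.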